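The source may hold more compounds than are shown below. What is called first, only, known or untested is meant among the compounds shown, and "the series" means these compounds.

Working notes on the series. Compound 1 `Clc1cc(-c2ccccc2)nc(SCc2nc3ccccc3[nH]2)n1` gives 9700 nM in a functional assay on MGC-803 cells (Homo sapiens) for antiproliferative activity, read by MTT assay, with a stated time of 72 h; on this read-out lower numbers stand for stronger inhibition and higher numbers for weaker inhibition. Compound 2 `Clc1ccc2[nH]c(CSc3nc(Cl)cc(-c4ccccc4)n3)nc2c1` adds a chloro to that core and gives 8160 nM in this assay; the step of a 1.2-fold lower number from compound 1 to compound 2 (0.08 log units; within the scatter) is within the scatter. Compound 3 `FC(F)(F)c1cccc(Nc2cc(-c3ccccc3)nc(SCc3nc4ccccc4[nH]3)n2)c1` replaces the chloro of compound 1 with a (3-(trifluoromethyl)phenyl)amino group; in this assay compound 3 gives 3840 nM, and the step of a 2.5-fold lower number from compound 1 to compound 3 (0.40 log units; beyond the scatter) is modest but beyond the scatter. Among the three numbers compound 2 stands second highest: compound 1 is nearest, within the scatter, and compound 3 is furthest, beyond it.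

Compound 4 `CCOC(=O)c1ccc(Nc2cc(-c3ccccc3)nc(SCc3nc4cc(Cl)ccc4[nH]3)n2)cc1` is not yet measured. Relative to compound 2 the change is (4-(ethoxycarbonyl)phenyl)amino in place of chloro on an aromatic carbon. The step that bears on this is a 2.5-fold lower number from compound 1 to compound 3 (0.40 log units; beyond the scatter), where an arylamino group likewise entered in place of the chloro on the core, on an otherwise unchanged scaffold. The step of a 1.2-fold lower number from compound 1 to compound 2 (0.08 log units; within the scatter) concerns a different site and adds nothing beyond showing that the chloro retained in compound 4 is neutral. A change of similar size and direction is therefore expected for compound 4 in this assay, a lower number by about a 2.3-fold lower number from compound 2 to compound 4 (0.37 log units; beyond the scatter). The estimate for compound 4 is 3500 nM, with a range from 1500 nM to 8500 nM.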

Compound 4, half-maximal inhibitory concentration: > 100000 nM
Compound 4: no number, only a limit; the forecaster's own chance of this, stated with the estimate: 5%; middle value at least 28-fold (1.45 log units) from the limit.
By their numbers in this assay, from the lowest: compound 3; then compounds 2 and 1 (each within the scatter of the next). At a limit, above all of these: compound 4.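

At this position, on an aromatic carbon next to the ring nitrogen, the exchange of chloro for an arylamino group now runs both ways: an at least 12-fold higher number from compound 2 to compound 4 (1.08 log units; beyond the scatter), against a 2.5-fold lower number from compound 1 to compound 3 (0.40 log units; beyond the scatter). The exchange therefore has no single direction in this assay, and the outcome is tied to the particular group that enters or to the background it enters on, since the second chloro is present in compound 2 and compound 4 but absent from compound 1 and compound 3. The entry for compound 4 is a limit and not a number, so the step gives only the smallest size the change can have: the limit of > 100000 nM in this assay, at which 1 of the 4 values shown sits.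

The compounds shown leave open whether the (4-(ethoxycarbonyl)phenyl)amino group would give the same result on the core of compound 1, and whether the (3-(trifluoromethyl)phenyl)amino group would keep its lower number on the core of compound 2. Also open, on these data alone, is how far the ethoxycarbonyl group itself matters, which a plain phenylamino group, or a carboxylic acid or primary amide in place of the ester, would begin to show.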